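Adding a Chloro Group to Compound 3's Core

The source may report more compounds than this note shows. Statements on the series, on what has been measured and on what is new or still open speak of the compounds shown alone.

Three measured compounds share one core and differ only in a single group on its nitrogen-containing ring. In a functional assay on MT2 cells (Homo sapiens) for cytotoxicity, read by MTT assay (a lower number here means that less compound is tolerated, a higher number that more compound is tolerated), compound 1 `CC(C)=CCOc1cc(Nc2nccc(C(F)(F)F)n2)ccc1Cl` gives 2500 nM. Compound 2 `COc1ccnc(Nc2ccc(Cl)c(OCC=C(C)C)c2)n1` gives 9000 nM, and compound 3 `CC(C)=CCOc1cc(Nc2nccc(N)n2)ccc1Cl` gives 500 nM. The three swaps all moved the numbers beyond the scatter: a 3.6-fold higher number from compound 1 to compound 2 (0.56 log units; beyond the scatter), a 5.0-fold lower number from compound 1 to compound 3 (0.70 log units; beyond the scatter), and an 18-fold lower number from compound 2 to compound 3 (1.26 log units; beyond the scatter). Compound 3 therefore stands with the lowest number of the three, meaning the least compound is tolerated by the cells.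

Compound 4 `CC(C)=CCOc1cc(Nc2nc(N)cc(Cl)n2)ccc1Cl` keeps the amino group of compound 3 and adds one more group: chloro in place of hydrogen on an aromatic carbon. Going by the values given here, none of the measured steps touches this position, so no step bears directly on the change; the measured steps only show that single-group changes on this ring shifted the read-out by modest to large amounts in either direction. With no guide to direction, the expected outcome for compound 4 is a number close to that of compound 3, with a wide range that allows a shift of the size seen in the measured steps. The step of a 1.2-fold higher number from compound 3 to compound 4 (0.08 log units; within the scatter) is the estimated change, and compound 4 is expected to give 600 nM, with a range from 150 nM to 2500 nM.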

Compound 4, half-maximal cytotoxic concentration: 14 nM
The estimate for compound 4 lay 43-fold (1.63 log units) above the measured number; measured number below the stated range.
By their numbers in this assay, from the lowest: compound 4; then compound 3; then compound 1; then compound 2.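

In this assay, chloro in place of hydrogen on an aromatic carbon gives a 36-fold lower number from compound 3 to compound 4 (1.55 log units; beyond the scatter), so a single added heavy atom produces a large change beyond the scatter. Going by these compounds alone, this position, next to the ring nitrogen and meta to an amino group, carries hydrogen in compounds 1, 2 and 3, so the earlier steps could say nothing about it; the new step shows that the read-out is highly sensitive to a change here, with less compound tolerated once chloro is present. No available evidence explains how this one chlorine has so large an effect on the cells.

The compounds shown leave open whether this shift is particular to chloro or would also follow from another group at the same place, such as a fluorine atom, a methyl group or a methoxy group. They also leave open whether the same chloro would lower the number as far if the amino group of compound 4 were replaced by the trifluoromethyl of compound 1 or the methoxy of compound 2.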